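The compounds below may be only part of what the source reports. "The series", "measured", "known", "first", "only" and "open" are said of these compounds alone.

Three compounds with a shared core set the scene. Compound 1 `CSc1ccc(CNc2nc(SC)nc3ncccc23)cc1` gives 50 nM in a functional assay on MCF7 cells (Homo sapiens) for cytotoxicity, read by MTT assay, with a stated time of 72 h; a higher number here means a weaker inhibitor of growth, a lower number a stronger inhibitor of growth. Compound 2 `Sc1nc(NCc2ccccc2)c2ccccc2n1` gives 27200 nM in this assay, and compound 3 `CSc1nc(NCc2ccc([Se]C)cc2)c2ccccc2n1` gives 36400 nM. On these numbers compound 2 stands second highest of the three: its nearest neighbour is compound 3, whose number lies within the scatter of it, while compound 1 lies far below it, beyond the scatter.

The step now followed leads from compound 2 to compound 4 `C[Se]c1nc(NCc2ccccc2)c2ccccc2n1`, which is not yet measured. The change is a group of 2 heavy atoms (1 carbon, 1 selenium; no ring) in place of one sulfur atom, on an aromatic carbon: in words, a group of two heavy atoms, one carbon and one selenium, in place of one sulfur atom on an aromatic carbon, between two ring nitrogen atoms of the core.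

For the measured compounds named here, no measured pair shows this change directly, so the size of the step is open. Compound 3, which carries a carbon and sulfur on the same position of the same core, sits near compound 2 in this assay. Compound 4 is therefore expected to stay in the same high region, with a step from compound 2 to compound 4 of a 1.2-fold lower number from compound 2 to compound 4 (0.09 log units; within the scatter) that need not pass beyond the scatter. The estimate for compound 4 is 22000 nM, within a range from 5000 nM to 90000 nM.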

Compound 4, concentration for 50% growth inhibition: 15800 nM
Compound 4: the middle estimate sits 1.4-fold (0.14 log units) above what was measured; the measured number falls inside the stated range.
By their numbers in this assay, from the lowest: compound 1; then compounds 4, 2 and 3 (each within the scatter of the next, the first and the last beyond it).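

In this assay, for the compounds shown here, the first direct reading at this position, a group of 2 heavy atoms (1 carbon, 1 selenium) in place of the sulfanyl group on the aromatic carbon between two ring nitrogen atoms gives a 1.7-fold lower number from compound 2 to compound 4 (0.24 log units; within the scatter), so the change leaves the number in the same high region. The sulfanyl group counts 1 hydrogen-bond donor and 1 hydrogen-bond acceptor and the entering group 0 of each, yet in this one pair that difference comes with no step beyond the scatter. No measurement at hand offers an explanation for this small step.

As far as these compounds go, whether an amine, a hydroxyl group or a longer chain at this position would stay in the same region remains open. Also open, from the compounds shown here alone, is whether the same exchange would give a step of similar size on the core of compound 1, which stands at 50 nM.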